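Compound 3: Dropping the Amino Link Before the Carbonyl

The source may report more compounds than this note shows. Statements on the series, on what has been measured and on what is new or still open speak of the compounds shown alone.

Of the compounds shown here, two built on a shared core have been tested in a functional assay on UO-31 cells (Homo sapiens) for inhibition, read by sulforhodamine B assay, with a stated time of 48 h, tested at 100 uM; on this read-out higher numbers stand for a weaker effect at the one concentration tested and lower numbers for a stronger effect. Compound 1 `COc1cc(Cl)cc(-c2nn(-c3cccc(NC(=O)Nc4ccc(Cl)c(Cl)c4)c3)cc2-c2ccncc2)c1` gives -10%. Compound 2 `COc1cc(Cl)cc(-c2nn(-c3cccc(NC(=O)Nc4cccc(C(F)(F)F)c4)c3)cc2-c2ccncc2)c1` gives -20%, which is the lower of the two numbers, but the step of a number 10 percentage points lower from compound 1 to compound 2 (within the scatter) lies within the scatter, so no real difference between the two can be claimed.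

Compound 3 `COc1cc(Cl)cc(-c2nn(-c3cccc(NC(=O)c4cccc(C(F)(F)F)c4)c3)cc2-c2ccncc2)c1` has not yet been measured. It differs from compound 2 in one place: 3-(trifluoromethyl)phenyl in place of (3-(trifluoromethyl)phenyl)amino on a carbonyl carbon. Going by the values given here, the only measured step, from compound 1 to compound 2, exchanged one ring for another on an amide-type nitrogen and left the carbonyl and its neighbours untouched, so it carries no information about removing the amino portion. With nothing to lean on beyond two numbers that sit close together, the expectation for compound 3 is a step of a number 8 percentage points higher from compound 2 to compound 3 (within the scatter), nothing beyond the scatter, held with wide uncertainty. Compound 3 is therefore estimated at -12% in this assay, with a range from -50% to 40%.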

Compound 3, a percentage reported as activity, at one concentration (the size of the read-out at that concentration, not a potency): 37%
Estimate against measurement, compound 3: 49 percentage points below; measured number inside the range.
By their numbers in this assay, from the lowest: compounds 2 and 1 (each within the scatter of the next); then compound 3.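

In this assay the group on the carbonyl carbon matters far more than the earlier comparison could show: the ring exchange on the amide-type nitrogen gave only a number 10 percentage points lower from compound 1 to compound 2 (within the scatter) whereas putting 3-(trifluoromethyl)phenyl in place of (3-(trifluoromethyl)phenyl)amino gives a number 57 percentage points higher from compound 2 to compound 3 (beyond the scatter) and the parallel comparison with the 3,4-dichlorophenyl partner gives a number 47 percentage points higher from compound 1 to compound 3 (beyond the scatter) as well. Since a higher number stands for a weaker effect here, the amino link goes with the stronger effect among these three compounds, and losing it removes both a nitrogen and the hydrogen-bond donor counted in the leaving group. Nothing measured here explains why the effect weakens when that link is lost.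

Still open, going by these compounds, is whether the nitrogen itself or its hydrogen is what counts: a methylamino link would keep the nitrogen without that hydrogen, while a methylene link would put a carbon in its place. On these data alone, it is also open whether the same loss would appear with other rings on the carbonyl carbon, such as a pyridine, and whether the weaker effect seen at the one concentration tested would also appear at other concentrations.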